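Compound 4 against the limit of the assay

A few compounds are considered here, and "the series" means these few. Any claim that something is new, unique, unknown or untested is made for them only; others in the source may bear on it.

In a functional assay on MDA-MB-231 cells (Homo sapiens) for antiproliferative activity, read by MTT assay, with a stated time of 24 h (a lower number here means a stronger inhibitor, a higher number a weaker inhibitor), compound 1 (`O=C(NNc1ccccc1F)c1ccc(NS(=O)(=O)c2cnc(O)nc2O)cc1`) reads > 20000 nM as a limit. Compound 2 (`O=C(NNc1ccccc1F)c1ccccc1NS(=O)(=O)c1cnc(O)nc1O`) reads > 20000 nM as a limit too, so it stands without a number. Compound 3 (`O=C(NNC(=O)c1ccccc1F)c1ccc(NS(=O)(=O)c2cnc(O)nc2O)cc1`) reads > 20000 nM as a limit as well. For the measured compounds named here, the series so far therefore rests on the limit of > 20000 nM in this assay, at which 3 of the 3 values shown sit, and offers no numerical anchor.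

Compound 4 (`Cc1ccc(C(=O)NNC(=O)c2ccccc2NS(=O)(=O)c2cnc(O)nc2O)cc1`) differs from compound 2 by (4-methylphenyl)carbonyl in place of 2-fluorophenyl on an amine nitrogen and carries (4-methylphenyl)carbonyl in place of 2-fluorophenyl on an amine nitrogen. Going by the values given here, the one measured step of a similar kind is a step that the two limits leave unreadable from compound 1 to compound 3 with (2-fluorophenyl)carbonyl in place of 2-fluorophenyl on an amine nitrogen. It gives neither a size nor a direction. No step beyond the scatter is expected in this assay and another limit is the likeliest reading. The estimated change is a step that the limit leaves unreadable from compound 2 to compound 4 and remains only an expectation. Compound 4 is estimated at 25000 nM with an expected range from 8000 nM to 60000 nM if a number is reported at all.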

Compound 4, half-maximal inhibitory concentration: > 20000 nM
Compound 4: no number, only a limit; the forecaster's own chance of this, stated with the estimate: 75%; the middle value is on the limit's open side.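

Compound 2 and compound 4 both read only as limits in this assay, so no step can be read between them. The compounds shown leave open which change to the shared core, if any, gives a measurable number, as the series rests entirely on one value: the limit of > 20000 nM in this assay, at which 4 of the 4 values shown sit.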